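The source may report more compounds than this note shows. Statements on the series, on what has been measured and on what is new or still open speak of the compounds shown alone.

Measured so far:
- Compound 1, `N#Cc1ccc(C(c2ccc(C#N)cc2)n2cc(C3CCCCC3)nn2)cc1`: 19300 nM
- Compound 2, `Cc1ccc(OCc2cn(C(c3ccc(C#N)cc3)c3ccc(C#N)cc3)nn2)cc1`: 11000 nM
- Compound 3, `c1ccc(C(c2ccccc2)n2ccnn2)cc1`: 4580 nM

In an assay on isolated protein for inhibition of Aromatase (Homo sapiens), read by fluorescence and colorimetric assay, with a stated time of 30 min (a lower number here means a stronger inhibitor, a higher number a weaker inhibitor), compound 3 gives the lowest number of the three, and both compound 2 and compound 1 lie beyond the scatter above it. Compound 4, `Clc1ccc(OCc2cn(C(c3ccccc3)c3ccccc3)nn2)cc1`, is made from compound 3 by (4-chlorophenoxy)methyl in place of hydrogen on an aromatic carbon. Going by the values given here, no measured step adds a group to a bare hydrogen at this carbon. Among the compounds with values here, the only step that touches the same carbon is the exchange of cyclohexyl for (4-methylphenoxy)methyl, a 1.8-fold lower number from compound 1 to compound 2 (0.24 log units; within the scatter), which changed little. Compound 1 and compound 2 both carry a large group there and both give higher numbers than compound 3, but they also carry two nitriles, so that gap cannot be laid to the group alone. The expectation is therefore a modest rise in the number, with wide uncertainty. Compound 4 is expected near 7000 nM, somewhere between 2500 nM and 20000 nM. This estimate amounts to an expected step of a 1.5-fold higher number from compound 3 to compound 4 (0.18 log units; within the scatter).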

Compound 4, half-maximal inhibitory concentration: 13400 nM
Compound 4: middle estimate off by 1.9-fold (0.28 log units), on the low side; the measured number falls inside the stated range.
By their numbers in this assay, from the lowest: compound 3; then compounds 2, 4 and 1 (each within the scatter of the next).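

Going by these compounds alone, this is the first direct reading of a group added to the bare hydrogen on this aromatic carbon of the five-membered ring. With the rest of the core unchanged, in this assay (4-chlorophenoxy)methyl in place of hydrogen gives a 2.9-fold higher number from compound 3 to compound 4 (0.47 log units; beyond the scatter), a step beyond the usual scatter, whereas the earlier exchange of one large group for another, a 1.8-fold lower number from compound 1 to compound 2 (0.24 log units; within the scatter), stayed within it. Nothing available explains the rise in the number.

Open, from the compounds shown here alone, is whether a much smaller group at this carbon, such as a single methyl or an aminomethyl, would raise the number as well, or whether the phenoxy ring and its chlorine matter. Open too, going by these compounds, is how the same addition behaves on the core carrying two nitriles.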